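Replacing a bicyclic group with a pentenyl chain

The source may hold more compounds than are shown below. What is called first, only, known or untested is meant among the compounds shown, and "the series" means these compounds.

Compound 3 `CC(C(=O)NCc1ccc(C(F)(F)F)nc1C1CC2CCC1C2)c1ccc(NS(C)(=O)=O)c(F)c1` gives 1.5 nM in an assay on CHO cells for antagonist activity at transient receptor potential cation channel subfamily V member 1 (Homo sapiens), read by FLIPR and calcium flux (on this read-out higher numbers stand for weaker inhibition and lower numbers for stronger inhibition), which is the highest of the three numbers recorded so far, although both of the other compounds sit within the usual scatter of it. Compound 1 `CCCCCc1nc(C(F)(F)F)ccc1CNC(=O)C(C)c1ccc(NS(C)(=O)=O)c(F)c1` gives 1 nM in this assay, and compound 2 `C[C@H](C(=O)NCc1ccc(C(F)(F)F)nc1C1CC2CCC1C2)c1ccc(NS(C)(=O)=O)c(F)c1` gives 0.8 nM in this assay. Among the compounds with values here, the step of a 1.5-fold higher number from compound 1 to compound 3 (0.18 log units; within the scatter) is too small to count, and the step of a 1.9-fold higher number from compound 2 to compound 3 (0.27 log units; within the scatter) is likewise within the scatter; the only difference in that pair is the fact that one of compounds 2 and 3 is drawn with a defined configuration and the other without, at the place where they differ.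

Compound 4 `CCC/C=C/c1nc(C(F)(F)F)ccc1CNC(=O)C(C)c1ccc(NS(C)(=O)=O)c(F)c1` is the next one to be measured in this assay. Relative to compound 3 the change is a group of 5 heavy atoms (5 carbon; no ring) in place of a group of 7 heavy atoms (7 carbon; 2 five-membered non-aromatic rings of carbon only), on an aromatic carbon. Within the data shown here, the only measured step that bears on this change is a 1.5-fold higher number from compound 1 to compound 3 (0.18 log units; within the scatter), which went the other way, from a chain of five carbons to the bicyclic group, and stayed within the scatter. Compound 4 returns to a five-carbon chain, now carrying one double bond, so no step beyond the scatter is expected in either direction in this assay. Compound 4 is therefore estimated to give 1.2 nM, with a range from 0.4 nM to 4 nM. This estimate corresponds to an expected step of a 1.3-fold lower number from compound 3 to compound 4 (0.10 log units; within the scatter).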

Compound 4, inhibition constant: 0.9 nM
The estimate for compound 4 lay 1.3-fold (0.12 log units) above the measured number; the range from low to high includes it.
By their numbers in this assay, from the lowest: compounds 2, 4, 1 and 3 (each within the scatter of the next).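

At the aromatic carbon next to the ring nitrogen, this assay now shows a third group with no readable change: pent-1-en-1-yl in place of the bicyclic group gives a 1.7-fold lower number from compound 3 to compound 4 (0.22 log units; within the scatter), so the earlier comparison of this bicyclic group with pentyl is joined by a second chain that also stays within the scatter of it. Within the data shown here, the new pair with compound 1 isolates the double bond for the first time, and pent-1-en-1-yl in place of pentyl gives a 1.1-fold lower number from compound 1 to compound 4 (0.05 log units; within the scatter), so adding this double bond to the five-carbon chain leaves no difference that can be read in this assay. Nothing in the information at hand gives a reason why these three groups are so closely matched at this position.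

As far as these compounds go, all three groups at this position are made of carbon only, so it remains open whether a longer chain, an amine or a carboxylic acid on the same aromatic carbon would also stay within the scatter. From the compounds shown here alone, compound 4 is drawn without a configuration at the saturated chain carbon, and how its S form would compare also remains open.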